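Chloro for fluoro on a second position of the core

The source may report more compounds than this note shows. Statements on the series, on what has been measured and on what is new or still open speak of the compounds shown alone.

Measured compounds:
compound 1 `Nc1n[n+]([O-])c2c(F)cccc2[n+]1[O-]`, 2100 nM;
compound 2 `Nc1n[n+]([O-])c2c(Cl)cccc2[n+]1[O-]`, 550 nM;
compound 3 `Nc1n[n+]([O-])c2cc(F)ccc2[n+]1[O-]`, 1870 nM.

All three were tested in a functional assay on HT-29 cells (Homo sapiens) for inhibition; a lower number here means a stronger inhibitor, a higher number a weaker inhibitor. Compound 1 and compound 3 share the same atoms joined differently; the difference between the two cores is not broken down here, and their values lie within the scatter of each other. From compound 1 to compound 2 the change is chloro in place of fluoro on an aromatic carbon, and it gave a 3.8-fold lower number from compound 1 to compound 2 (0.58 log units; beyond the scatter).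

Compound 4 `Nc1n[n+]([O-])c2cc(Cl)ccc2[n+]1[O-]` is not yet measured. It arises from compound 3 by chloro in place of fluoro on an aromatic carbon. This is the same kind of change as before, though the place differs: in the earlier pair the carbon is ortho to a fused ring and meta to a fused ring, here it is meta to a fused ring and para to a fused ring. On the strength of that earlier step, compound 4 is expected to show a 3.4-fold lower number from compound 3 to compound 4 (0.53 log units; beyond the scatter) in this assay, so its estimated value is 550 nM, plausibly between 250 nM and 1200 nM.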

Compound 4, half-maximal inhibitory concentration: 730 nM
Compound 4: middle estimate off by 1.3-fold (0.12 log units), on the low side, and the stated range covers the measured number.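

Chloro in place of fluoro again gave a 2.6-fold lower number from compound 3 to compound 4 (0.41 log units; beyond the scatter) in this assay. Set beside the earlier step, the size of the change held up when it moved to a different place on the core: the same change on two cores in this assay, a 3.8-fold lower number (0.58 log units; beyond the scatter) from compound 1 to compound 2 and a 2.6-fold lower number (0.41 log units; beyond the scatter) from compound 3 to compound 4, 1.5-fold (0.17 log units) apart, within the scatter of two such steps. This shows that the swap carried across these two pairs in this one test, but it does not show why the number falls or that the same would happen on a core bearing other groups.

Open, as far as these compounds go, is what bromo or methoxy on these aromatic carbons would give in this assay. Also open, from the compounds shown here alone, is whether the swap would hold if the free amine were replaced, for example by an acetamide.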